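This account rests on a few compounds, and the source may have more. Where it says the series, first, only, none or still open, it means among the compounds named here.

Three nucleosides sharing one core have been tested in a functional assay on K562 cells (Homo sapiens), read by MTT assay, with a stated time of 72 h; a higher number here means a weaker inhibitor, a lower number a stronger inhibitor. Compound 1 `CN(C)c1ncnc2c1c(-c1ccoc1)cn2[C@@H]1O[C@H](CO)[C@@H](O)[C@H]1O` gives 1540 nM in this assay. Compound 2 `COc1nc(N)nc2c1c(-c1ccccc1)cn2[C@@H]1O[C@H](CO)[C@@H](O)[C@H]1O` returns only a limit in this assay, reported as > 20000 nM. Compound 3 `Cc1nc(N)c2c(-c3ccco3)cn([C@@H]3O[C@H](CO)[C@@H](O)[C@H]3O)c2n1` likewise returns only a limit in this assay, reported as > 20000 nM. Compound 2 thus sits at the limit of > 20000 nM in this assay, at which 2 of the 3 values shown sit, so its position on the scale is known only as a boundary, and no number separates it from compound 3; compound 1 alone carries a measured value. Within the data shown here, no two of these three compounds differ in a single place, so no measured step exists to guide the next change. Compound 4 `COc1nc(N)nc2c1c(-c1cccs1)cn2[C@@H]1O[C@H](CO)[C@@H](O)[C@H]1O` is obtained from compound 2 by the change (thiophen-2-yl in place of phenyl on an aromatic carbon). In the absence of any measured step, the account expects the step in this assay to be small, none beyond the scatter, and the expected step is an at least 1.1-fold lower number from compound 2 to compound 4 (0.04 log units; that floor lies within the scatter). Compound 4 is accordingly estimated at 18000 nM, within a range from 4000 nM to 60000 nM, with a real chance that this assay again returns only a limit.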

Compound 4, half-maximal inhibitory concentration: > 20000 nM
Compound 4: only a limit was reported; the forecaster's own chance of this, stated with the estimate: 60%; middle value at least 1.1-fold (0.04 log units) from the limit.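

In this assay, among these compounds, compound 4 gives > 20000 nM as a limit, and compound 2 is also a limit, so no step between these two compounds can be read: the limit of > 20000 nM in this assay, at which 3 of the 4 values shown sit.

On these data alone, whether thiophen-2-yl in place of phenyl changes the number at all remains open.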